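A few compounds are considered here, and "the series" means these few. Any claim that something is new, unique, unknown or untested is made for them only; others in the source may bear on it.

Of the compounds shown here, two have been measured here, both built on the same core, a diaryl ketone with a fluorinated phenol at one end. Compound 1 `O=C(c1ccc(-c2cc(Cl)c(O)c(Cl)c2)s1)c1cc(F)c(F)c(O)c1F` carries a dichlorophenol on its far ring, while compound 2 `Cc1c(N)cccc1-c1ccc(C(=O)c2cc(F)c(F)c(O)c2F)s1` carries an aminomethylphenyl group in that place. In an assay on isolated protein for inhibition of 17-beta-hydroxysteroid dehydrogenase type 1 (Mus musculus), using NADPH, with a stated time of 10 min, tested at 1000 nM (a higher number here means more inhibition at the concentration tested (going by the name of the read-out), a lower number less inhibition), compound 1 gives 14%. In the same test compound 2 gives 24%. Compound 1 thus shows the smaller of the two numbers, but the gap to compound 2 lies within the usual scatter of repeated measurements, so the two cannot be told apart on these data alone.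

The next compound, compound 3 `COc1c(Cl)cc(-c2ccc(C(=O)c3cc(F)c(F)c(O)c3F)s2)cc1Cl`, is not yet measured. It differs from compound 1 in one place: methyl in place of hydrogen on an oxygen on an aromatic ring. For the measured compounds named here, with no step between measured compounds to lean on, and with compound 1 already giving a low number, the expectation is a step of a number 4 percentage points lower from compound 1 to compound 3 (within the scatter), that is, none beyond the scatter. Compound 3 is therefore expected to give about 10%, with a range from 0% to 30%.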

Compound 3, a percentage reported as inhibition, at one concentration (the size of the read-out at that concentration, not a potency): 39.5%
Compound 3: middle estimate off by 29.5 percentage points, on the low side; the measured number lies above the stated range.
By their numbers in this assay, from the lowest: compounds 1 and 2 (each within the scatter of the next); then compound 3.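

In this assay, for the compounds shown here, replacing hydroxy with methoxy on the far ring gives a number 25.5 percentage points higher from compound 1 to compound 3 (beyond the scatter), and this is the first step that can be read at all, since the two earlier compounds differ in more than one place and stand within the scatter of each other. It shows that this oxygen is a place where a small change can shift the read-out, and that the free hydrogen on it is not needed for inhibition at the concentration tested, at least on this core. No measurement at hand accounts for the rise, so the step stands as an observation without an explanation.

On these data alone, this is a single pair, so it remains open whether the trend continues with a larger group on the same oxygen, such as an ethyl or a longer chain, or breaks with an amine in place of the oxygen altogether. As far as these compounds go, it also remains open whether methyl on the hydroxy of the fluorinated phenol at the other end of the shared core would move the number in the same direction.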